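The source may report more compounds than this note shows. Statements on the series, on what has been measured and on what is new or still open speak of the compounds shown alone.

Compound 1 `CSc1nc(-c2cccs2)c(C#N)c(=O)n1C` was tested in a functional assay, with a stated time of 150 min (on this read-out higher numbers stand for weaker inhibition and lower numbers for stronger inhibition), where compound 1 gives 87 ug/mL. For the measured compounds named here, the only other measured compound, compound 2 `CCOC(=O)c1cnn(-c2nc(-c3ccccc3Cl)c(C#N)c(=O)n2C)c1N`, is built differently on the same core; in this assay compound 2 gives 93 ug/mL. Compound 1 thus carries the lower of the two numbers on record, but the gap to compound 2 lies within the scatter of repeated measurements, so the two cannot be told apart on these data, and neither can be called the stronger inhibitor.

The account now turns to compound 3 `CSc1nc(-c2ccco2)c(C#N)c(=O)n1C`, which has not yet been measured. It differs from compound 1 in one place only: furan-2-yl in place of thiophen-2-yl on an aromatic carbon. Going by the values given here, no step between two measured compounds with this kind of exchange is available, so there is nothing in the numbers to anchor its size.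

The expectation is that the step of a 1.1-fold higher number from compound 1 to compound 3 (0.04 log units; within the scatter) stays within the scatter, with no clear direction. On that basis compound 3 is expected to give about 95 ug/mL in this assay, estimated to fall between 45 ug/mL and 200 ug/mL.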

Compound 3, half-maximal inhibitory concentration: 108 ug/mL
For compound 3 the middle estimate is 1.1-fold (0.06 log units) below the measured one; the range from low to high includes it.
By their numbers in this assay, from the lowest: compounds 1, 2 and 3 (each within the scatter of the next).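

For the compounds shown here, the exchange of furan-2-yl for thiophen-2-yl, on the aromatic carbon next to the ring nitrogen and ortho to a cyano group, gives in this assay a 1.2-fold higher number from compound 1 to compound 3 (0.09 log units; within the scatter), the first step that can be read at this position. Both groups are five-membered aromatic rings with one hetero atom, and with sulfur or oxygen as that hetero atom, compound 1 and compound 3 cannot be told apart on this read-out, so this one exchange leaves the number inside the usual scatter. No accompanying measurement bears on this result, so the data offer nothing that could account for it.

Going by these compounds alone, this single step covers only two closely matched rings, so it remains open whether a carboxylic acid or a longer alkyl chain on the same aromatic carbon would shift the number beyond the scatter in either direction. The methylsulfanyl and methyl groups are also the same in compound 1 and compound 3, which leaves their contribution to inhibition unresolved by these compounds.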